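Ethoxy to isopropoxy on a shared core

The compounds below may be only part of what the source reports. "The series", "measured", "known", "first", "only" and "open" are said of these compounds alone.

Compound 1 `CCCO[C@@H]1C=CC(=O)[C@@H](CO)O1` gives 15600 nM in the test below
Compound 2 `CCO[C@@H]1C=CC(=O)[C@@H](CO)O1` gives 18000 nM in the same test
Compound 3 `CC(C)O[C@@H]1C=CC(=O)[C@@H](CO)O1` has no measurement yet

For the measured compounds named here, in a functional assay on NCI-H292 cells (Homo sapiens) for inhibition, read by MTT assay, with a stated time of 72 h (a higher number here means a weaker inhibitor, a lower number a stronger inhibitor), compound 2 gives 18000 nM and cannot be told apart from compound 1, the only other measured compound. Going by the values given here, the one measured step runs a 1.2-fold higher number from compound 1 to compound 2 (0.06 log units; within the scatter) and so stays within the scatter.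

The move to compound 3 is methyl in place of hydrogen on a saturated chain carbon bound to an oxygen on a saturated carbon and a saturated chain carbon and turns ethoxy into isopropoxy, with methyl in place of hydrogen on a saturated chain carbon bound to an oxygen on a saturated carbon and a saturated chain carbon. The step from compound 1 is the only one that bears on this, as it also concerns a single methyl on the chain, though on a different carbon. Among the compounds with values here, no measured compound carries a branched chain, so this support is indirect.

The size expected in this assay is therefore none beyond the scatter, in either direction. The estimate means a 1.1-fold lower number from compound 2 to compound 3 (0.02 log units; within the scatter) as the expected step. Compound 3 is estimated at 17000 nM with an expected range from 8500 nM to 34000 nM in this test.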

Compound 3, half-maximal inhibitory concentration: 24200 nM
Compound 3: middle estimate off by 1.4-fold (0.15 log units), on the low side; low and high end bracket the measured number.
By their numbers in this assay, from the lowest: compounds 1, 2 and 3 (each within the scatter of the next).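

In this assay, turning ethoxy into isopropoxy gives a 1.3-fold higher number from compound 2 to compound 3 (0.13 log units; within the scatter), and isopropyl in place of propyl on an oxygen on a saturated carbon gives a 1.6-fold higher number from compound 1 to compound 3 (0.19 log units; within the scatter). The earlier compounds had shown only a methyl added further out along a straight chain, whereas these steps show that a methyl on the saturated chain carbon bound to an oxygen on a saturated carbon, and with it a branched chain, produces no difference that this test can resolve, so that ethoxy, propoxy and isopropoxy cannot be told apart here. No other measurement on these compounds bears on this result.

On these data alone, whether a longer chain such as hexyl, a benzyl group or a chain ending in an amine or a carboxylic acid would move the number beyond the scatter remains open, since the three compounds span only small alkyl groups on that oxygen. Also open, as far as these compounds go, is whether a change elsewhere on the shared core would do so, as all three compounds carry that core unchanged.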